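The source may hold more compounds than are shown below. What is called first, only, known or untested is meant among the compounds shown, and "the series" means these compounds.

Measured compounds:
- Compound 1, `O=C(NCCCCc1ccccc1)n1c(=O)oc2cc(-c3ccc(F)cc3)ccc21`, gives 79 nM
- Compound 2, `COc1ccc(-c2ccc3c(c2)oc(=O)n3C(=O)NCCCCc2ccccc2)cc1`, gives 67 nM
- Compound 3, `COc1ccc(-c2ccc3oc(=O)n(C(=O)NCCCCc4ccccc4)c3c2)cc1`, gives 67 nM

All three numbers come from an assay on HEK293 cells for inhibition of acid ceramidase (Homo sapiens), with a stated time of 10 min; a lower number here means a stronger inhibitor, a higher number a weaker inhibitor. Compound 2 and compound 3 contain the same atoms joined differently; the difference between their two cores is not broken down here. In this assay compound 3 stands level with compound 2, and compound 1 lies within the usual scatter of both, so no ranking among the three can be claimed.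

One structural change appears twice in this set. Going from compound 2 to compound 1 it is fluoro in place of methoxy on an aromatic carbon, and it produced a 1.2-fold higher number from compound 2 to compound 1 (0.07 log units; within the scatter). Compound 4, `O=C(NCCCCc1ccccc1)n1c(=O)oc2ccc(-c3ccc(F)cc3)cc21`, has not yet been measured; it is related to compound 3 by fluoro in place of methoxy on an aromatic carbon, the same change in the same kind of place.

Compound 4 is therefore expected to give 80 nM in this assay, with a likely range from 40 nM to 160 nM. That expectation rests on compound 3 giving 67 nM and on the earlier step of a 1.2-fold higher number from compound 2 to compound 1 (0.07 log units; within the scatter), so the expected step of a 1.2-fold higher number from compound 3 to compound 4 (0.08 log units; within the scatter) is small.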

Compound 4, half-maximal inhibitory concentration: 56 nM
Estimate against measurement, compound 4: 1.4-fold (0.15 log units) above; measured number inside the range.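

In this assay, fluoro in place of methoxy on an aromatic carbon gave a 1.2-fold lower number from compound 3 to compound 4 (0.08 log units; within the scatter), a step too small to count as a real change. Set beside the earlier step, the two seem to point in opposite directions, but the gap between them is no larger than repeated measurements could produce: the same change on two cores in this assay, a 1.2-fold higher number (0.07 log units; within the scatter) from compound 2 to compound 1 and a 1.2-fold lower number (0.08 log units; within the scatter) from compound 3 to compound 4, 1.4-fold (0.15 log units) apart, within the scatter of two such steps. So, on these two cores, the change from 4-methoxyphenyl to 4-fluorophenyl leaves the number within the scatter each time, but this does not show that either group is better, that the cores respond in opposite ways, or that the same would hold on any other core.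

Going by these compounds, what a different group on the same aromatic carbon would do remains open, for example chloro, trifluoromethyl, nitrile or an amine, including whether any of them would move the number beyond the scatter. Also open, on these data alone, is how a shorter or longer version of the chain shared by all four compounds would behave.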